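A few compounds are considered here, and "the series" means these few. Any claim that something is new, unique, unknown or untested is made for them only; others in the source may bear on it.

Measured so far:
- compound 1, `Cc1cc(OC(=O)C(C)(C)CCC(CO[N+](=O)[O-])O[N+](=O)[O-])n(-c2ccccc2)n1`: 2500 nM
- compound 2, `O=C(O)CCCCCO[N+](=O)[O-]`: 8300 nM

In a functional assay on thoracic aorta (Rattus norvegicus, strain Wistar) for inhibition (a higher number here means that more compound is needed for the effect, a lower number that less compound is needed), compound 2 gives 8300 nM, the highest of the two numbers shown. Among the compounds with values here, compound 1, a compound of different build with two nitrate groups, gives 2500 nM in this assay, and the gap between the two lies beyond the usual scatter; no single-point step connects them, so only the two values themselves can be compared.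

Compound 3, `O=[N+]([O-])OCCCCCCO`, is not yet measured. It differs from compound 2 in one place: hydroxymethyl in place of carboxy on a saturated chain carbon, five bonds along the chain from an oxygen on an unsaturated carbon. Within the data shown here, no matched step of this kind stands among the measured compounds, so the expectation rests on the value of compound 2 alone. For compound 3 a modest step toward a lower number in this assay is expected, a 1.7-fold lower number from compound 2 to compound 3 (0.22 log units; within the scatter), though a result within the scatter of compound 2 would not surprise. The estimate for compound 3 is 5000 nM, with a range from 1500 nM to 20000 nM.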

Compound 3, half-maximal effective concentration: 1500 nM
Beside the measured number, compound 3's estimate is 3.3-fold (0.52 log units) above it, within the range that was stated.
By their numbers in this assay, from the lowest: compounds 3 and 1 (each within the scatter of the next); then compound 2.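

In this assay, within the data shown here, hydroxymethyl in place of carboxy gives a 5.5-fold lower number from compound 2 to compound 3 (0.74 log units; beyond the scatter), the first step that can be read at a single place. The effect on thoracic aorta therefore does not depend on the carboxy group at this position, and the change in end group shifts the number by more than the scatter. Nothing at hand explains the size of this step.

With only one replacement shown, it remains open whether the step reflects the loss of carboxy or the gain of hydroxymethyl; a methyl ester, an amide or a primary amine at this position would help separate the two. Also open, from the compounds shown here alone, is whether the same replacement gives a similar step on a shorter or longer chain.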